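A few compounds are considered here, and "the series" means these few. Any claim that something is new, unique, unknown or untested is made for them only; others in the source may bear on it.

The study compares four bromopropanamides built on two closely related cores. Compound 1 `CC(Br)C(=O)Nc1cc(C(=O)NC(N)=O)ccc1F` and compound 2 `CC(Br)C(=O)Nc1ccc(F)c(C(=O)NC(N)=O)c1` are made of the same atoms joined differently; the difference between the two cores is not broken down here. In a functional assay on CCRF-CEM cells (Homo sapiens) for antiproliferative activity, read by trypan blue exclusion, with a stated time of 72 h (a lower number here means a stronger inhibitor, a higher number a weaker inhibitor), compound 1 gives 3130 nM, while compound 2 gives 520 nM, the lowest number of the three measured compounds. Compound 3 `CC(Br)C(=O)Nc1cc(C(=O)NC(N)=O)ccc1Cl` derives from compound 1 by the change (chloro in place of fluoro on an aromatic carbon), and in this assay compound 3 gives 9800 nM. That change produced a 3.1-fold higher number from compound 1 to compound 3 (0.50 log units; beyond the scatter).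

Compound 4 `CC(Br)C(=O)Nc1ccc(Cl)c(C(=O)NC(N)=O)c1` is the corresponding partner of compound 2, reached by the change (chloro in place of fluoro on an aromatic carbon). Within the data shown here, it is the same kind of change as the one from compound 1 to compound 3, but the surroundings differ: in compound 3 the entering chloro sits ortho to a ((1-bromoethyl)carbonyl)amino group and para to a carbamoylcarbamoyl group, whereas in compound 4 it sits ortho to a carbamoylcarbamoyl group and para to a ((1-bromoethyl)carbonyl)amino group.

Among the measured compounds shown here, with only one earlier example of this exchange, the expectation is that compound 4 moves in the same direction as compound 3, giving an estimated 3.1-fold higher number from compound 2 to compound 4 (0.49 log units; beyond the scatter) in this assay, because compound 1 to compound 3 showed a 3.1-fold higher number from compound 1 to compound 3 (0.50 log units; beyond the scatter). Compound 4 is therefore expected to give about 1600 nM, likely between 600 nM and 4500 nM.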

Compound 4, half-maximal inhibitory concentration: 2550 nM
Compound 4: the middle estimate sits 1.6-fold (0.20 log units) below what was measured; measured number inside the range.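

In this assay, the exchange of fluoro for chloro on the core of compound 2 gives a 4.9-fold higher number from compound 2 to compound 4 (0.69 log units; beyond the scatter) and thus runs the same way as on the core of compound 1. Set side by side, the two steps do not differ beyond what repeated measurement would give, and on this pair of cores the exchange carries over in both direction and size: the same change on two cores in this assay, a 3.1-fold higher number (0.50 log units; beyond the scatter) from compound 1 to compound 3 and a 4.9-fold higher number (0.69 log units; beyond the scatter) from compound 2 to compound 4, 1.6-fold (0.19 log units) apart, within the scatter of two such steps. Among these compounds, this rests on only two steps and on two cores made of the same atoms joined differently; it shows that the exchange carried over here, not that it would do so on any further core, and it does not tell why chloro gives the higher number on both.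

The compounds shown leave open how other groups on that aromatic carbon, such as hydrogen, methyl, methoxy or a nitrile, would compare with fluoro and chloro on either core. They also leave open whether the same agreement between the cores would hold for a change elsewhere in the molecule, for instance chlorine or an amine in place of the bromine of the 1-bromoethyl group.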